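The source may report more compounds than this note shows. Statements on the series, on what has been measured and on what is new or still open speak of the compounds shown alone.

Measured compounds in this series:
- compound 1 `Cc1c(OCCCCOc2ccc(Cl)c(C(=O)O)c2)ccc(C(=O)CC(C)(C)C)c1O` gives 130 nM
- compound 2 `CNC(=O)c1cc(OCCCCOc2ccc(C(=O)CC(C)(C)C)c(O)c2C)ccc1F` gives 476 nM
- compound 3 `COc1ccc(OCCCCOc2ccc(C(=O)CC(C)(C)C)c(O)c2C)cc1C(=O)O` gives 490 nM

All three numbers come from an assay for positive allosteric modulation of metabotropic glutamate receptor 3 (Rattus norvegicus); a higher number here means that more compound is needed for the effect, a lower number that less compound is needed. Compound 1 stands lowest of the three; compound 2 and compound 3 are both beyond the scatter above it, and the two of them lie within the scatter of each other.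

Within the data shown here, the only single-point step measured so far is a 3.8-fold higher number from compound 1 to compound 3 (0.58 log units; beyond the scatter), a modest rise on the aryl ring at the far end of the four-carbon linker. The step to compound 4 `Cc1c(OCCCCOc2ccc(C(=O)O)c(F)c2)ccc(C(=O)CC(C)(C)C)c1O` alters the same ring more broadly: 4-carboxy-3-fluorophenyl in place of 3-carboxy-4-chlorophenyl on an oxygen on a saturated carbon. Among the measured compounds shown here, no measured pair isolates the move of the carboxy group or the halogen swap, so the step from compound 1 to compound 3 is the closest guide, and compound 2 shows that a second variant of this ring also sits well above compound 1.

A rise of similar size in this assay is therefore expected for compound 4, roughly a 2.7-fold higher number from compound 1 to compound 4 (0.43 log units; beyond the scatter), giving an estimate of 350 nM with a range of 120 nM to 1000 nM.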

Compound 4, half-maximal effective concentration: 1110 nM
Compound 4: middle estimate off by 3.2-fold (0.50 log units), on the low side, outside the stated range (above it).
By their numbers in this assay, from the lowest: compound 1; then compounds 2 and 3 (each within the scatter of the next); then compound 4.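

In this assay the step to 4-carboxy-3-fluorophenyl in place of 3-carboxy-4-chlorophenyl on an oxygen on a saturated carbon gives an 8.5-fold higher number from compound 1 to compound 4 (0.93 log units; beyond the scatter), and compound 4 now has the highest number of the series. Compound 1 remains lowest, with all three other variants of this ring beyond the scatter above it, so none of them matches 3-carboxy-4-chlorophenyl here. Nothing at hand accounts for the size of this rise.

Compound 4 changes the halogen and the carboxy placement together, so the share of each in the rise stays unresolved. Also open, as far as these compounds go, is how the number would respond to a tetrazole in place of the carboxy group, or to a bromine in place of the chlorine of compound 1.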